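Chain terminus swap in the tetrahydropyran series

The source may report more compounds than this note shows. Statements on the series, on what has been measured and on what is new or still open speak of the compounds shown alone.

Among the compounds with values here, compound 2 `CCCCCC/C=C/C[C@H]1C[C@@H]([C@@H](O)c2ccccc2)CO[C@@H]1c1ccccc1` gives 4990 nM in a functional assay on HL-60 cells (Homo sapiens) for cytotoxicity, read by WST assay, with a stated time of 48 h (a higher number here means a weaker inhibitor, a lower number a stronger inhibitor), the lower of the two numbers so far; compound 1 `Oc1cccc(/C=C/C[C@H]2C[C@@H]([C@@H](O)c3ccccc3)CO[C@@H]2c2ccccc2)c1` gives 12800 nM. Within the data shown here, the only measured step, a 2.6-fold lower number from compound 1 to compound 2 (0.41 log units; beyond the scatter), is modest. Compound 3 `O[C@@H](c1ccccc1)[C@H]1CO[C@H](c2ccccc2)[C@@H](C/C=C/c2ccccc2)C1` differs from compound 2 by phenyl in place of hexyl on a double-bonded chain carbon bound to a double-bonded chain carbon. This partly reverses the step to compound 2, though phenyl lacks the hydroxyl of compound 1, so a rise not clearly beyond the scatter is expected, as a 1.6-fold higher number from compound 2 to compound 3 (0.20 log units; within the scatter). Compound 3 is therefore estimated at 8000 nM, in the range 3500 nM to 18000 nM.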

Compound 3, half-maximal inhibitory concentration: 7040 nM
Estimate against measurement, compound 3: 1.1-fold (0.06 log units) above; low and high end bracket the measured number.
By their numbers in this assay, from the lowest: compounds 2, 3 and 1 (each within the scatter of the next, the first and the last beyond it).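

Phenyl in place of hexyl on a double-bonded chain carbon bound to a double-bonded chain carbon gives a 1.4-fold higher number from compound 2 to compound 3 (0.15 log units; within the scatter) in this assay, so hexyl and phenyl are not told apart at this position. Hydrogen in place of hydroxy on an aromatic carbon gives a 1.8-fold lower number from compound 1 to compound 3 (0.26 log units; within the scatter), so the hydroxy group of compound 1 is not told apart from hydrogen either, and only compound 1 and compound 2 remain separated. No supporting data bear on these results.

From the compounds shown here alone, whether an amine, a carboxylic acid or a chain longer than hexyl at this position would shift the number stays open. Going by these compounds, the effect of changes on the shared core also stays open.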